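The source may hold more compounds than are shown below. What is called first, only, known or untested is meant among the compounds shown, and "the series" means these compounds.

Measured compounds:
Compound 1, `C[C@H](Nc1cc(F)c(S(=O)(=O)Nc2nccs2)cc1Cl)c1ccc(F)cc1`, gives 3.1.
Compound 2, `C[C@H](Nc1cc(F)c(S(=O)(=O)Nc2nccs2)cc1Cl)c1ccc(F)cc1F`, gives 3.6.
Compound 3, `C[C@H](Nc1cc(F)c(S(=O)(=O)Nc2cscn2)cc1Cl)c1ccccc1`, gives 3.2.

The three compounds were measured in a physicochemical assay for lipophilicity, read by LC-MS, in phosphate buffer, measured as octanol-water partition, with a stated time of 1 h, at pH 7.4; on this read-out lower numbers stand for lower lipophilicity and higher numbers for higher lipophilicity. Compound 1 and compound 2 differ by one change, (fluoro in place of hydrogen on an aromatic carbon), and the step was a number 0.50 log units higher from compound 1 to compound 2 (beyond the scatter). Compound 3 has a different core; how the two cores differ is not broken down here. Compound 4, `C[C@H](Nc1cc(F)c(S(=O)(=O)Nc2cscn2)cc1Cl)c1ccccc1F`, has not yet been measured; it differs from compound 3 by fluoro in place of hydrogen on an aromatic carbon. This is the same kind of change as that from compound 1 to compound 2, though there the entering fluoro also sits meta to a fluoro group, which is not the case in compound 4. Resting on the step of a number 0.50 log units higher from compound 1 to compound 2 (beyond the scatter), a step of about a number 0.40 log units higher from compound 3 to compound 4 (beyond the scatter) is expected in this assay. Compound 4 is therefore estimated at 3.6, between 3.3 and 3.9.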

Compound 4, distribution coefficient: 3.5
Compound 4: the middle estimate sits 0.10 log units above what was measured, within the range that was stated.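

On the second core, fluoro in place of hydrogen on an aromatic carbon gave in this assay a step of a number 0.30 log units higher from compound 3 to compound 4 (within the scatter), set against a number 0.50 log units higher from compound 1 to compound 2 (beyond the scatter) on the core of compound 1. The change thus points the same way on both cores, but the step on the second core stays within the scatter and so cannot by itself be told from no change, and a single pair per core, with a fluoro already present on the ring of compound 1, establishes no general rule for carrying the change across. Nothing available bears on why the two steps read as they do.

The compounds shown leave open how a chloro, methoxy or nitrile group in the place of this fluoro would read on either core. They also leave open whether an amine or a carboxylic acid on the phenyl ring would behave alike on both cores.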